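The compounds below may be only part of what the source reports. "The series", "measured", "known", "first", "only" and "open" are said of these compounds alone.

Measured so far in an assay on isolated protein for inhibition of MAP kinase-interacting serine/threonine-protein kinase 2 (Homo sapiens), read by HTRF, in the presence of a further agent that is not named here; on this read-out lower numbers stand for stronger inhibition and higher numbers for weaker inhibition:

Compound 1 `Cc1c(C(=O)N2CCOCC2)oc2ccc(Nc3ncnc4ccc(Cl)nc34)cc12` gives 1800 nM.
Compound 2 `Cc1c(C(=O)N(C)C)oc2ccc(Nc3ncnc4ccc(Cl)nc34)cc12` gives 2200 nM.
Compound 3 `Cc1c(C(=O)N2CCNCC2)oc2ccc(Nc3ncnc4ccc(Cl)nc34)cc12` gives 1900 nM.

Compound 3 holds the second highest of the three numbers, but its nearest neighbour is compound 1 and its furthest is compound 2, and both gaps fall within the usual scatter, so the three compounds cannot be set in any order on this assay.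

The next compound is compound 4 `CCCNC(=O)c1oc2ccc(Nc3ncnc4ccc(Cl)nc34)cc2c1C`. From compound 3 the change is propylamino in place of piperazin-1-yl on a carbonyl carbon.

Bearing on this are the three steps already made on the carbonyl carbon: a 1.2-fold higher number from compound 1 to compound 2 (0.09 log units; within the scatter), a 1.1-fold higher number from compound 1 to compound 3 (0.02 log units; within the scatter) and a 1.2-fold lower number from compound 2 to compound 3 (0.06 log units; within the scatter). None of them leaves the scatter, so exchanging the group on the carbonyl carbon among those three choices has not shifted the read-out. Propylamino is a fourth choice at the same place, and on that basis no step beyond the scatter is expected; the expected step is a 1.1-fold higher number from compound 3 to compound 4 (0.02 log units; within the scatter). Compound 4 is therefore estimated at 2000 nM, with a range from 1000 nM to 4200 nM.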

Compound 4, half-maximal inhibitory concentration: 1900 nM
Estimate against measurement, compound 4: 1.1-fold (0.02 log units) above, and the stated range covers the measured number.
By their numbers in this assay, from the lowest: compounds 1, 3, 4 and 2 (each within the scatter of the next).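

In this assay, propylamino on the carbonyl carbon gives no change at the digits printed from compound 3 to compound 4 (within the scatter), a 1.2-fold lower number from compound 2 to compound 4 (0.06 log units; within the scatter) and a 1.1-fold higher number from compound 1 to compound 4 (0.02 log units; within the scatter). Among these compounds, compound 4 is the first of the series to carry the amide hydrogen, and its propyl chain replaces the rings of compound 1 and compound 3, yet none of these steps leaves the scatter, so this place has now taken rings and open chains, with and without the amide hydrogen, without a measurable shift. No measured information on the compounds accounts for this flat result.

Going by these compounds, what remains open is whether any group on the carbonyl carbon can move the read-out at all. A carboxylic acid in place of the amide, or a longer chain ending in an amine, would test that.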